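Lengthening a Side Chain: Expected Cytotoxicity of Compound 3

The source may report more compounds than this note shows. Statements on the series, on what has been measured and on what is new or still open speak of the compounds shown alone.

Compound 1 `Cc1cc(C)c(Nc2ncnc(Nc3ccc(C#N)cc3)n2)c(C)c1` gives 7000 nM in an ADME assay on MT2 cells (Homo sapiens) for inhibition; on this read-out lower numbers stand for higher toxicity in this test and higher numbers for lower toxicity in this test.
Compound 2 `Cc1cc(C)c(Nc2nc(Nc3ccc(C#N)cc3)nc(OCCC3CCNCC3)n2)c(C)c1` gives 4200 nM.

Within the data shown here, compound 2 stands at the low end of these two numbers, yet the only measured step, a 1.7-fold lower number from compound 1 to compound 2 (0.22 log units; within the scatter), lies within the scatter, so nothing separates the two. Compound 3 `Cc1cc(C)c(Nc2nc(Nc3ccc(C#N)cc3)nc(OCCCC3CCNCC3)n2)c(C)c1` differs from compound 2 by (piperidin-4-yl)methyl in place of piperidin-4-yl on a saturated chain carbon, two bonds along the chain from an oxygen on an aromatic ring. Among the measured compounds shown here, no measured step alters the length of this chain; the single step that concerns the chain at all, adding it whole, stayed within the scatter. For compound 3 no step beyond the scatter is therefore expected, a 1.1-fold lower number from compound 2 to compound 3 (0.02 log units; within the scatter). Compound 3 is estimated at 4000 nM, between 1500 nM and 11000 nM.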

Compound 3, half-maximal cytotoxic concentration: 4000 nM
Compound 3: the middle estimate sits on the measured number at the digits printed; the range from low to high includes it.
By their numbers in this assay, from the lowest: compounds 3, 2 and 1 (each within the scatter of the next).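

Lengthening 2-(piperidin-4-yl)ethoxy to 3-(piperidin-4-yl)propoxy gives a 1.1-fold lower number from compound 2 to compound 3 (0.02 log units; within the scatter) in this assay and so, for the first time, tests the length of this chain directly. The longer side chain, in place of hydrogen on an aromatic carbon, likewise gives a 1.8-fold lower number from compound 1 to compound 3 (0.24 log units; within the scatter) on the same read-out. Nothing available explains these small differences. Still open, on these data alone, is whether a longer chain, or a carboxylic acid in place of the piperidin-4-yl ring, would move the number beyond the scatter.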